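A few compounds are considered here, and "the series" means these few. Any claim that something is new, unique, unknown or untested is made for them only; others in the source may bear on it.

Measured compounds:
Compound 1 `O=C(Nc1ccc(-n2ccc3nc(C(=O)NCc4ccccc4)ccc32)cc1)Nc1cccc(Cl)c1Cl` in a functional assay on A375P cells (Homo sapiens) for cytotoxicity, read by MTT assay (on this read-out lower numbers stand for stronger inhibition and higher numbers for weaker inhibition), gives > 10000 nM, which is a limit of this assay and not a number.
Compound 2 `COC(=O)c1ccc2c(ccn2-c2ccc(NC(=O)Nc3ccc(Cl)c(C(F)(F)F)c3)cc2)n1` gives 3600 nM in this assay.
Compound 3 `NC(=O)c1ccc2c(ccn2-c2ccc(NC(=O)Nc3cccc(Cl)c3Cl)cc2)n1` gives 4600 nM in this assay.

Compound 1 stands at the weak end of what is shown: its value is the limit of this assay (the limit of > 10000 nM in this assay, at which 1 of the 3 values shown sits), so its true potency is known only as lying beyond that limit. Within the data shown here, the one step that starts from compound 1 is an at least 2.1-fold lower number from compound 1 to compound 3 (0.33 log units; beyond the scatter), a change on the other side of the shared core; it tells nothing about the carbonyl end that is changed here. Among the measured compounds shown here, compound 2 and compound 3 differ from each other in two places, so their values are simply two numbers of similar size and no single step can be drawn between them.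

Compound 4 `O=C(Nc1ccc(-n2ccc3nc(C(=O)NCc4ccccc4)ccc32)cc1)c1ccc(Cl)c(C(F)(F)F)c1` differs from compound 1 by 4-chloro-3-(trifluoromethyl)phenyl in place of (2,3-dichlorophenyl)amino on a carbonyl carbon. For the measured compounds named here, no measured step touches this kind of change, so the expectation rests on compound 1 alone, and compound 1 offers only a limit. Compound 4 is therefore expected to remain near that limit, with a wide range: the estimate is 9000 nM, between 2000 nM and 40000 nM, corresponding to an expected step of an at least 1.1-fold lower number from compound 1 to compound 4 (0.04 log units; that floor lies within the scatter).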

Compound 4, half-maximal inhibitory concentration: 700 nM
The estimate for compound 4 lay 13-fold (1.11 log units) above the measured number, and the stated range ends above it.
By their numbers in this assay, from the lowest: compound 4; then compounds 2 and 3 (each within the scatter of the next). At a limit, above all of these: compound 1.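

In this assay, the carbonyl end of the molecule is shown for the first time to carry a large effect: placing 4-chloro-3-(trifluoromethyl)phenyl in place of (2,3-dichlorophenyl)amino on a carbonyl carbon gives an at least 14-fold lower number from compound 1 to compound 4 (1.15 log units; beyond the scatter). Among these compounds, compound 4 keeps the benzyl group on its amide-type nitrogen, so that group does not by itself hold a compound at the limit, even though the only earlier step concerned its replacement by hydrogen. The step is a floor and not an exact size, as compound 1 has a limit and not a number: the limit of > 10000 nM in this assay, at which 1 of the 4 values shown sits.

The change exchanges the amino nitrogen and the ring's substituents at once, so the compounds shown do not separate the two; a 2,3-dichlorophenyl group placed directly on the carbonyl carbon, or a (4-chloro-3-(trifluoromethyl)phenyl)amino group in the same place on the benzyl amide series, would begin to do so. As far as these compounds go, it also remains open whether the effect holds with a methyl ester or a primary amide at the other end of the shared core, or with a cyclohexyl ring on the carbonyl carbon.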